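The compounds below may be only part of what the source reports. "The series", "measured", "known", "first", "only" and "open" are said of these compounds alone.

Measured so far in an assay on cell membranes for displacement of a labelled ligand from Cholecystokinin receptor type A (Rattus norvegicus), read by CCK-8 assay, with a stated time of 2 h; a higher number here means a weaker inhibitor, a lower number a stronger inhibitor:
Compound 1 `CN1C(=O)C=C(Cl)C1(O)c1ccc(Cl)cc1` gives 2000 nM.
Compound 2 `CC(C)N1C(=O)C=C(Cl)C1(O)c1ccccc1` gives 200 nM.
Compound 3 `CC(C)N1C(=O)C=C(Cl)C1(O)c1ccc(Cl)cc1` gives 300 nM.

Among these three, compound 2 carries the lowest number. Compound 3 sits nearest to it, and the step of a 1.5-fold higher number from compound 2 to compound 3 (0.18 log units; within the scatter) stays within the scatter, so the two cannot be ranked against each other. Compound 1 lies furthest away, and its value and that of compound 2 are separated by a gap that lies beyond the scatter.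

Compound 4 `CC(C)(C)N1C(=O)C=C(Cl)C1(O)c1ccccc1` differs from compound 2 by methyl in place of hydrogen on a saturated chain carbon bound to an amide-type nitrogen in a ring and two saturated chain carbons. Among the measured compounds shown here, the one measured step that bears on growth of this alkyl group is a 6.7-fold lower number from compound 1 to compound 3 (0.82 log units; beyond the scatter), where the same nitrogen substituent was enlarged by one branch and the number fell by a modest amount. For the measured compounds named here, no measured pair shows what a second enlargement does, and the change from compound 2 to compound 4 is smaller in count than that earlier one. Compound 4 is therefore expected to show a small lowering in this assay, with a real chance that the step of a 1.5-fold lower number from compound 2 to compound 4 (0.19 log units; within the scatter) ends up within the scatter. The estimate for compound 4 is 130 nM, with a range from 40 nM to 400 nM.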

Compound 4, half-maximal inhibitory concentration: 120 nM
Compound 4: middle estimate off by 1.1-fold (0.03 log units), on the high side; the range from low to high includes it.
By their numbers in this assay, from the lowest: compounds 4, 2 and 3 (each within the scatter of the next, the first and the last beyond it); then compound 1.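

In this assay, the change from isopropyl to tert-butyl on the amide-type nitrogen in the ring gives a 1.7-fold lower number from compound 2 to compound 4 (0.22 log units; within the scatter) and so adds a single methyl without a change that can be told from the scatter. The earlier enlargement at this nitrogen, from methyl to isopropyl, gave a 6.7-fold lower number from compound 1 to compound 3 (0.82 log units; beyond the scatter) and lay beyond the scatter, so at this position a step beyond the scatter is now set against one within it, although the first pair carries chloro on the aromatic carbon and the second carries hydrogen there. No measurement offered here explains how these two steps at the nitrogen compare.

The compounds shown do not tell how tert-butyl on this nitrogen behaves with chloro in place of hydrogen on the aromatic carbon, so the two enlargements cannot yet be compared on one background. They also leave open what a longer chain such as n-butyl, a cyclohexyl ring or a chain ending in an amine would do on the same nitrogen.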